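Three Limits and a Chlorophenyl Amide Still Untested

A few compounds are considered here, and "the series" means these few. Any claim that something is new, unique, unknown or untested is made for them only; others in the source may bear on it.

Compound 1 `COc1ccc(NC(=O)c2cccc(/C=C3\CC(=O)N(c4ccccc4)C3=O)c2)c(C)c1`, compound 2 `Cc1ccc(N2C(=O)C/C(=C\c3cccc(C(=O)Nc4ccc(Cl)cc4)c3)C2=O)cc1` and compound 3 `O=C(NCC1CCCCC1)c1cccc(/C=C2\CC(=O)N(c3ccccc3)C2=O)c1` share one core and differ only in the groups on their two nitrogens. In an ADME assay on HCT-116 cells (Homo sapiens) for cytotoxicity, read by MTT assay, with a stated time of 72 h (a lower number here means a stronger inhibitor, a higher number a weaker inhibitor), compound 1 gives only a limit, > 100000 nM. In this assay compound 2 also gives a limit, > 100000 nM. Compound 3 likewise stops at a limit, > 100000 nM. Among the measured compounds shown here, the single step between compounds differing in one place, a step that the two limits leave unreadable from compound 1 to compound 3, therefore cannot be read, as the limit of > 100000 nM in this assay, at which 3 of the 3 values shown sit, shows. Compound 4 `O=C(Nc1ccc(Cl)cc1)c1cccc(/C=C2\CC(=O)N(c3ccccc3)C2=O)c1` differs from compound 3 by 4-chlorophenyl in place of cyclohexylmethyl on an amide-type nitrogen; compound 2 already carries the (4-chlorophenyl)carbamoyl group. With no readable step for guidance, in this assay compound 4 is expected to reach a limit again, near 100000 nM (from 40000 nM to 300000 nM). The expected step is thus a number no higher from compound 3 to compound 4 (the limit leaves the size open), nothing beyond the scatter.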

Compound 4, half-maximal inhibitory concentration: > 100000 nM
Compound 4 was reported as a limit; the forecaster's own chance of this, stated with the estimate: 85%; the middle value lies on the limit itself.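

In this assay compound 4 also stops at a limit, so none of its steps from compound 1, compound 2 or compound 3 can be read: the limit of > 100000 nM in this assay, at which 4 of the 4 values shown sit.
The compounds shown leave open whether changing the group on either nitrogen alters cytotoxicity at all.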